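A few compounds are considered here, and "the series" means these few. Any claim that something is new, unique, unknown or untested is made for them only; others in the source may bear on it.

Measured so far:
compound 1, `CCCCCCCC#Cc1cc2cn(COCCO)c(=O)nc2o1` — 200000 nM
compound 2, `CCCCCCCCCc1cc2cn(COCCO)c(O)nc-2n1` — > 80000 nM
compound 3, `CO[C@H]1[C@H](O)[C@@H](O)[C@@H](O)O[C@@H]1C(=O)O` — > 100000 nM

In a functional assay on HEL cells (Homo sapiens), read by microscopy (on this read-out lower numbers stand for higher toxicity in this test and higher numbers for lower toxicity in this test), compound 1 gives 200000 nM, the only actual number among the three shown. For compound 2 the assay reports only a limit, > 80000 nM. For compound 3 it likewise reports only a limit, > 100000 nM. Going by the values given here, compound 1 is thus the sole fixed point, and no step between measured compounds can be drawn. Compound 4, `CCCCCC#Cc1cc2cn(COCCO)c(=O)nc2o1`, differs from compound 1 in one place: hydrogen in place of ethyl on a saturated chain carbon, five bonds along the chain from a triple-bonded carbon. With a single number to lean on, the expected step is no change at the digits printed from compound 1 to compound 4 (within the scatter), none beyond the scatter. Compound 4 is accordingly estimated at 200000 nM, with a range of 100000 nM to 400000 nM, and a limit rather than a number would not surprise.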

Compound 4, minimum cytotoxic concentration: >= 100000 nM
Compound 4 ended at the assay's limit; the forecaster's own chance of this, stated with the estimate: 40%; the middle value does not contradict the limit.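

In this assay, going by these compounds alone, compound 4 gives only a limit, >= 100000 nM, and no step from compound 1 to compound 4 can be read. The compounds shown leave open whether hydrogen in place of ethyl changes the read-out in this assay at all.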